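A few compounds are considered here, and "the series" means these few. Any claim that something is new, unique, unknown or untested is made for them only; others in the source may bear on it.

Working notes on the series. In a physicochemical assay for pharmacokinetics (on this read-out higher numbers stand for a longer-lived compound and lower numbers for a shorter-lived compound), compound 1 `O=C(NCc1ccccc1Br)N1C(=O)c2ccccc2S1(=O)=O` gives > 166 h as a limit of the assay and not as a number. Compound 2 `O=C(NCc1ccccc1F)N1C(=O)c2ccccc2S1(=O)=O` gives > 166 h in this assay and this too is only a limit. Compound 3 `O=C(c1ccccc1)N1Cc2ccccc2S1(=O)=O` gives > 166 h and that is again a limit. Going by the values given here, the series so far rests entirely on the limit of > 166 h in this assay, at which 3 of the 3 values shown sit, and so compound 2 has no readable number, only a limit.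

The change under study leads from compound 2 to compound 4 `Cc1ccccc1CNC(=O)N1C(=O)c2ccccc2S1(=O)=O` and reads methyl in place of fluoro on an aromatic carbon in words: methyl in place of fluoro on an aromatic carbon, or 2-fluorophenyl to 2-methylphenyl. Among the compounds with values here, the one measured step that bears on it is a step that the two limits leave unreadable from compound 1 to compound 2 with fluoro in place of bromo on an aromatic carbon. That step gives no size to carry over and no direction. No step beyond the usual scatter is therefore expected in this assay and the compound is expected to stay long-lived like its neighbours. The expected move is a step that the limit leaves unreadable from compound 2 to compound 4 and it is estimated only loosely. For compound 4 the estimate is 220 h with an expected range from 130 h to 450 h and a reading that is most likely a limit again.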

Compound 4, half-life: > 166 h
Compound 4 ended at the assay's limit; the forecaster's own chance of this, stated with the estimate: 85%; the middle value does not contradict the limit.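

In this assay compound 4 gives > 166 h as a limit and not as a number. Going by these compounds alone, no new step from compound 1 or compound 2 to compound 4 can be read, and the comparison rests on a single limit: the limit of > 166 h in this assay, at which 4 of the 4 values shown sit. The compounds shown leave open what number any of them would give and how compound 1, compound 2 and compound 4 compare in this assay.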